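The source may hold more compounds than are shown below. What is called first, only, known or untested is meant among the compounds shown, and "the series" means these compounds.

Measured compounds in a functional assay on NCI-H292 cells (Homo sapiens) for cytotoxicity, read by MTT assay, with a stated time of 72 h, tested at 10 ug/mL; a higher number here means more inhibition of growth at the concentration tested, a lower number less inhibition of growth:
compound 1 `O=C1NC(=S)/C(=C/c2ccccc2Br)S1` with 36.9%
compound 2 `O=C1NC(=S)/C(=C/c2ccccc2Cl)S1` with 45%

Compound 2 holds the highest of the two numbers in this assay, though its nearest neighbour compound 1 sits within the scatter, as the step of a number 8.1 percentage points higher from compound 1 to compound 2 (within the scatter) shows. Compound 3 `O=C1NC(=S)/C(=C/c2c(Cl)cccc2Cl)S1` carries the change (chloro in place of hydrogen on an aromatic carbon). Among the compounds with values here, the only measured step, a swap of one halogen for another, was within the scatter; no measured step adds a second chloro group, so the size of a number 3 percentage points higher from compound 2 to compound 3 (within the scatter) is uncertain and compound 3 is expected near compound 2. Compound 3 is estimated at 48%, within 30% to 66%.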

Compound 3, percent growth inhibition at one concentration: 32.8%
Estimate against measurement, compound 3: 15.2 percentage points above; low and high end bracket the measured number.
By their numbers in this assay, from the lowest: compounds 3, 1 and 2 (each within the scatter of the next, the first and the last beyond it).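

In this assay, chloro in place of hydrogen, on an aromatic carbon ortho to the group of 8 heavy atoms and meta to a chloro group, gives a number 12.2 percentage points lower from compound 2 to compound 3 (beyond the scatter). This position therefore responds to substitution, and a second chloro group here lowers the number, whereas the swap of one halogen for another stayed within the scatter. Nothing available explains this drop. Going by these compounds, whether a methoxy group or an amine at this position would lower the number as well remains open. So does whether the drop is specific to chloro.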